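The source may report more compounds than this note shows. Statements on the series, on what has been measured and on what is new or still open speak of the compounds shown alone.

Compound 1 `O=C1O[C@@H](CN2CCCCC2)CN1c1ccc(-n2cc(-c3ccccn3)cn2)c(F)c1` gives > 400 ug/mL in an ADME assay on L02 cells (Homo sapiens) for cytotoxicity, read by MTT assay, with a stated time of 48 h (a lower number here means a stronger inhibitor, a higher number a weaker inhibitor), a limit of the assay.
Compound 2 `O=C1CSC(=O)N1C[C@H]1CN(c2ccc(-n3cc(-c4ccccn4)cn3)c(F)c2)C(=O)O1` gives > 400 ug/mL in this assay, a limit of the assay.
Compound 3 `CC(=O)OC[C@H]1CN(c2ccc(-n3cc(-c4ccccn4)cn3)c(F)c2)C(=O)O1` gives > 400 ug/mL in this assay, a limit of the assay.

Compound 1 stands only at a limit in this assay, and the two other values shown are limits as well (the limit of > 400 ug/mL in this assay, at which 3 of the 3 values shown sit). Compound 4 `COC(=O)NC[C@H]1CN(c2ccc(-n3cc(-c4ccccn4)cn3)c(F)c2)C(=O)O1` differs from compound 1 by (methoxycarbonyl)amino in place of piperidin-1-yl on a saturated chain carbon bound to a saturated ring carbon. The measured steps at this place, a step that the two limits leave unreadable from compound 1 to compound 2, a step that the two limits leave unreadable from compound 1 to compound 3 and a step that the two limits leave unreadable from compound 2 to compound 3, are all unreadable between limits, so no size or direction can be drawn from them. The step of a number no higher from compound 1 to compound 4 (the limit leaves the size open) is therefore expected to stay within the scatter, most likely again as a limit. The estimate for compound 4 is 400 ug/mL, with a range from 200 ug/mL to 800 ug/mL.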

Compound 4, half-maximal inhibitory concentration: 71 ug/mL
For compound 4 the middle estimate is 5.6-fold (0.75 log units) above the measured one; measured number outside the range, below it.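

In this assay this position proves able to move the number: (methoxycarbonyl)amino in place of piperidin-1-yl gives an at least 5.6-fold lower number from compound 1 to compound 4 (0.75 log units; beyond the scatter) and in place of acetoxy gives an at least 5.6-fold lower number from compound 3 to compound 4 (0.75 log units; beyond the scatter) and in place of 2,4-dioxo-1,3-thiazolidin-3-yl gives an at least 5.6-fold lower number from compound 2 to compound 4 (0.75 log units; beyond the scatter). From the compounds shown here alone, the true size of each step remains open, and the steps among the other compounds cannot be read. Compound 1, compound 2 and compound 3 each stand at a limit: the limit of > 400 ug/mL in this assay, at which 3 of the 4 values shown sit.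

The compounds shown leave open whether the lower number goes with the amide hydrogen or with the methoxycarbonyl part. A free amine or an acetylamino group at this place could tell these apart.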